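The source may report more compounds than this note shows. Statements on the series, on what has been measured and on what is new or still open speak of the compounds shown alone.

Measured so far in a functional assay on the whole organism (Sciatic nerve) for inhibition, with Rattus norvegicus as the target, at a dose of 25 mg/kg; a higher number here means more inhibition at the dose given (going by the name of the read-out), a lower number less inhibition:
compound 1 `O=C(O)Cc1nn(Cc2nc3ccccc3s2)c(=O)c2ccccc12` gives 67%
compound 2 `O=C(O)Cc1nn(Cc2nc3cc(F)ccc3s2)c2ccc(Cl)cc12` gives 34%
compound 3 `O=C(O)Cc1nn(Cc2nc3cc(F)cc(F)c3s2)c2ccc(Cl)cc12` gives 69%

Compound 3 stands highest of the three numbers, though compound 1 lies within the scatter of it and only compound 2 is clearly lower. Among the compounds with values here, the one step measured, a number 35 percentage points higher from compound 2 to compound 3 (beyond the scatter), concerns the fluoro and not the chloro.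

Compound 4 `O=C(O)Cc1nn(Cc2nc3cc(F)cc(F)c3s2)c2ccccc12` differs from compound 3 by hydrogen in place of chloro on an aromatic carbon. Within the data shown here, no measured step bears directly on removing the chloro. Compound 1, which carries neither the chloro nor any fluoro, and compound 3 show values within the scatter of each other, so the chloro is not evidently needed. The step of a number 9 percentage points lower from compound 3 to compound 4 (within the scatter) is therefore expected to be small, likely none beyond the scatter. Compound 4 is estimated at 60%, in the range 40% to 78%.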

Compound 4, a percentage reported as inhibition, in the whole organism at one dose (the size of the read-out at that dose, not a potency): 61%
For compound 4 the middle estimate is 1 percentage points below the measured one, within the range that was stated.
By their numbers in this assay, from the lowest: compound 2; then compounds 4, 1 and 3 (each within the scatter of the next).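

In this assay, within the data shown here, hydrogen in place of chloro gives a number 8 percentage points lower from compound 3 to compound 4 (within the scatter), the first direct reading of this change. With the two fluoro groups in place, this aromatic carbon therefore carries either hydrogen or chloro with no difference beyond the scatter, so the chloro is not needed for the read-out at this dose. Nothing on hand accounts for this result. Among these compounds, open is whether a methoxy group or an amine at this carbon would hold the number, and whether removing the chloro would be equally quiet with the single fluoro of compound 2.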